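The source may hold more compounds than are shown below. What is called first, only, known or untested is meant among the compounds shown, and "the series" means these compounds.

Measured so far:
compound 1 `COc1cc(NCc2ccc(C)s2)ccc1-c1cnco1` gives 24700 nM
compound 2 `COc1cc(/N=C/c2cccs2)ccc1-c1cnco1` gives 406000 nM
compound 3 `COc1cc(/N=C/c2ccncc2)ccc1-c1cnco1` gives 239000 nM

In an ADME assay on Vero cells (Chlorocebus sabaeus) for cytotoxicity, read by MTT assay, with a stated time of 96 h (a higher number here means that more compound is tolerated, a lower number that less compound is tolerated), compound 1, at 24700 nM, gives the lowest of the three numbers, and the numbers of the other two lie beyond the scatter above it. Compound 4 `COc1cc(NCc2cncs2)ccc1-c1cnco1` carries 1,3-thiazol-5-yl in place of 5-methylthiophen-2-yl on a saturated chain carbon bound to a nitrogen on an aromatic ring. Among the measured compounds shown here, only one measured step bears on this change, and only loosely, as it swaps pyridin-4-yl for thiophen-2-yl on a carbon with a double bond to nitrogen. That step, a 1.7-fold lower number from compound 2 to compound 3 (0.23 log units; within the scatter), stays within the scatter. No step beyond the scatter is therefore expected in this assay. The expected change is a 1.1-fold higher number from compound 1 to compound 4 (0.05 log units; within the scatter). Compound 4 is estimated at 28000 nM, with an expected range of 9000 nM to 90000 nM.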

Compound 4, half-maximal cytotoxic concentration: 232000 nM
For compound 4 the middle estimate is 8.3-fold (0.92 log units) below the measured one; the measured number lies above the stated range.
By their numbers in this assay, from the lowest: compound 1; then compounds 4, 3 and 2 (each within the scatter of the next).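

In this assay, the swap at this saturated chain carbon gives a 9.4-fold higher number from compound 1 to compound 4 (0.97 log units; beyond the scatter), so a change of one aromatic ring for another can move the number beyond the scatter here. The change joins two differences, the loss of the methyl and the added ring nitrogen, and this single step cannot separate them. Nothing measured on hand explains the step.

As far as these compounds go, it remains open whether the methyl or the ring nitrogen accounts for the step. A 5-methyl-1,3-thiazol-2-yl group or an unsubstituted furan-2-yl group on the same chain carbon would extend the comparison.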